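Swapping 1-phenylethyl for (pyridin-4-yl)methyl on the shared core

The source may report more compounds than this note shows. Statements on the series, on what has been measured and on what is new or still open speak of the compounds shown alone.

- compound 1 `Cc1noc(-c2nc(C)c3c(c2N)C(=O)N(Cc2ccc(C(F)(F)F)cc2)C3=O)n1` gives < 5000 nM (a limit, not a number)
- compound 2 `Cc1noc(-c2nc(C)c3c(c2N)C(=O)N(Cc2cccc(C(F)(F)F)c2)C3=O)n1` gives < 5000 nM (a limit, not a number)
- compound 3 `Cc1noc(-c2nc(C)c3c(c2N)C(=O)N(C(C)c2ccccc2)C3=O)n1` gives 10900 nM (a true number)

In a physicochemical assay for solubility, using the shake flask method, in simulated intestinal fluid, measured as kinetic solubility, with a stated time of 2 h, at 25 degrees C, at pH 6.5 (on this read-out lower numbers stand for lower solubility and higher numbers for higher solubility), compound 3 gives 10900 nM and is the only one of the three with a true number. The other two values are limits, as shown by the limit of < 5000 nM in this assay, at which 2 of the 3 values shown sit.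

Compound 4 `Cc1noc(-c2nc(C)c3c(c2N)C(=O)N(Cc2ccncc2)C3=O)n1` carries (pyridin-4-yl)methyl in place of 1-phenylethyl on an amide-type nitrogen in a ring.

Among the compounds with values here, only one measured step exists, a step that the two limits leave unreadable from compound 1 to compound 2, and it concerns a different swap, so it gives no size to carry over. The expectation therefore rests on compound 3 at 10900 nM as the sole anchor in this assay.

The estimate is a 1.5-fold higher number from compound 3 to compound 4 (0.17 log units; within the scatter), a small upward step held loosely and not expected to clear the usual scatter.

For compound 4 the expected value is 16000 nM, with an estimated range from 5000 nM to 50000 nM.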

Compound 4, solubility: 26400 nM
For compound 4 the middle estimate is 1.7-fold (0.22 log units) below the measured one, and the stated range covers the measured number.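

In this assay, the position on the amide-type nitrogen in a ring now shows a change of readable size: a 2.4-fold higher number from compound 3 to compound 4 (0.38 log units; beyond the scatter) comes with (pyridin-4-yl)methyl in place of 1-phenylethyl. Against the two trifluoromethyl compounds, pyridin-4-yl gives an at least 5.2-fold higher number from compound 2 to compound 4 (0.72 log units; beyond the scatter) and an at least 5.2-fold higher number from compound 1 to compound 4 (0.72 log units; beyond the scatter) as minimum sizes, not exact ones. Those two steps have no upper size, and the step from compound 1 to compound 2 cannot be read, because both compounds sit at a limit: the limit of < 5000 nM in this assay, at which 2 of the 4 values shown sit.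

The change from 1-phenylethyl to (pyridin-4-yl)methyl alters both the aromatic ring and the chain, and the compounds shown do not separate those two parts. Going by these compounds, how an amine or a carboxylic acid at this position would read remains open.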